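Pentyl chain in place of methyl on the shared core

This account rests on a few compounds, and the source may have more. Where it says the series, first, only, none or still open, it means among the compounds named here.

Compound 1 `COc1ccc(Nc2cc(C)oc(=O)c2)cc1` is the starting point of this step. In a functional assay on DU-145 cells (Homo sapiens) for cytotoxicity, read by MTT assay, with a stated time of 72 h (a higher number here means that more compound is needed for the effect, a lower number that less compound is needed), compound 1 gives only a limit of the assay, > 30 uM, and no number; this is the limit of > 30 uM in this assay, at which 1 of the 3 values shown sits. Compound 2 `O=c1cc(Nc2ccc(Br)cc2)cc(-c2ccccc2)o1` gives 0.34 uM in this assay, and compound 3 `COc1ccccc1Nc1cc(-c2ccccc2)oc(=O)c1` gives 0.37 uM; each differs from compound 1 in more than one place, so only their two values are shown, no step. Compound 4 `CCCCCc1cc(Nc2ccc(OC)cc2)cc(=O)o1` differs from compound 1 by butyl in place of hydrogen on a saturated chain carbon bound to an aromatic carbon. Going by the values given here, no single-change step between measured compounds exists in this set. The step of an at least 3.7-fold lower number from compound 1 to compound 4 (0.57 log units; beyond the scatter) in this assay is expected to move the value off the limit to a measurable number, a gain beyond the usual scatter. For compound 4 the estimate is 8 uM, with a range from 1.5 uM to 30 uM.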

Compound 4, concentration for half-maximal effect: 5.94 uM
For compound 4 the middle estimate is 1.3-fold (0.13 log units) above the measured one, and the stated range covers the measured number.
By their numbers in this assay, from the lowest: compounds 2 and 3 (each within the scatter of the next); then compound 4. At a limit, above all of these: compound 1.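

Butyl in place of hydrogen on a saturated chain carbon bound to an aromatic carbon, the same difference as methyl to pentyl, gives in this assay the only single-change step in the series: an at least 5.0-fold lower number from compound 1 to compound 4 (0.70 log units; beyond the scatter). Compound 1 stands at a limit of the assay, so this step gives a bound and no exact size: the limit of > 30 uM in this assay, at which 1 of the 4 values shown sits. The chain at this position thus bears on the read-out, which compounds 2 and 3 could not show, as each differs from compound 1 in more than one place.

From the compounds shown here alone, whether a propyl chain, a longer chain such as octyl, or an amine at this position would lower the number further stays open.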